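Ethoxy Gives Way to Trifluoromethyl on the Pyridine Arm

The source may hold more compounds than are shown below. What is called first, only, known or untested is meant among the compounds shown, and "the series" means these compounds.

Compound 1 `Cc1nc(C)n(CC(=O)N2CCN(c3sc(C(F)(F)F)nc3-c3cnc(N4CCCC4)nc3)C[C@H]2C)n1` gives 352 nM in an assay on blood for inhibition of C-X-C chemokine receptor type 3 (Homo sapiens), with a stated time of 30 min; a lower number here means a stronger inhibitor, a higher number a weaker inhibitor. Compound 2 `CCOc1ccc(-c2nc(C(F)(F)F)sc2N2CCN(C(=O)Cn3nc(C)nc3C)[C@H](C)C2)cn1` gives 887 nM in this assay.

Within the data shown here, compound 2 carries the higher of the two numbers, and the only known step, a 2.5-fold higher number from compound 1 to compound 2 (0.40 log units; beyond the scatter), is what separates the pair. Compound 3 `Cc1nc(C)n(CC(=O)N2CCN(c3sc(C(F)(F)F)nc3-c3ccc(C(F)(F)F)nc3)C[C@H]2C)n1` differs from compound 2 by trifluoromethyl in place of ethoxy on an aromatic carbon. Among the measured compounds shown here, no measured step covers this exchange; the one known step concerns a different part of the molecule and offers no guidance here. A step within the scatter is therefore expected, and compound 3 is estimated at 1000 nM, ranging from 400 nM to 2500 nM, which means a 1.1-fold higher number from compound 2 to compound 3 (0.05 log units; within the scatter).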

Compound 3, half-maximal inhibitory concentration: 860 nM
For compound 3 the middle estimate is 1.2-fold (0.07 log units) above the measured one, and the stated range covers the measured number.
By their numbers in this assay, from the lowest: compound 1; then compounds 3 and 2 (each within the scatter of the next).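

On the pyridine carbon next to the ring nitrogen, swapping ethoxy, which has a hydrogen-bond acceptor, for trifluoromethyl, which has none, leaves this assay unmoved, with a 1.0-fold lower number from compound 2 to compound 3 (0.01 log units; within the scatter). Compound 3 also stays apart from the pyrrolidinyl pyrimidine arm of compound 1, at a 2.4-fold higher number from compound 1 to compound 3 (0.39 log units; beyond the scatter), so the two pyridine arms sit together in this comparison. No measurement on hand accounts for this match. From the compounds shown here alone, whether an amine or a carboxylic acid on this same carbon would also leave the number in place remains open.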